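From 1-aminocyclopentyl to 1-hydroxyethyl on the carbonyl carbon

The source may hold more compounds than are shown below. What is called first, only, known or untested is meant among the compounds shown, and "the series" means these compounds.

In a functional assay on NCI-H1975 cells (Homo sapiens) for antiproliferative activity (on this read-out lower numbers stand for stronger inhibition and higher numbers for weaker inhibition), compound 1 `Cc1c2c(n3c1CCN(C(=O)CN)C[C@@H](C)[C@H](C)Nc1cc-3ccc1C(N)=O)CC(C)(C)CC2=O` gives 190 nM, compound 2 `Cc1c2c(n3c1CCN(C(=O)C(C)(C)N)C[C@@H](C)[C@H](C)Nc1cc-3ccc1C(N)=O)CC(C)(C)CC2=O` gives 21 nM and compound 3 `Cc1c2c(n3c1CCN(C(=O)C1(N)CCCC1)C[C@@H](C)[C@H](C)Nc1cc-3ccc1C(N)=O)CC(C)(C)CC2=O` gives 26 nM. The step of a 1.2-fold higher number from compound 2 to compound 3 (0.09 log units; within the scatter) stays within the scatter, so compound 3 stands level with compound 2 and well apart from compound 1. The next structure, compound 4 `Cc1c2c(n3c1CCN(C(=O)[C@H](C)O)C[C@@H](C)[C@H](C)Nc1cc-3ccc1C(N)=O)CC(C)(C)CC2=O`, differs from compound 3 as follows: 1-hydroxyethyl in place of 1-aminocyclopentyl on a carbonyl carbon. The closest evidence comes from the two steps away from aminomethyl, a 9.0-fold lower number from compound 1 to compound 2 (0.96 log units; beyond the scatter) and a 7.3-fold lower number from compound 1 to compound 3 (0.86 log units; beyond the scatter), both beyond the scatter. Going by the values given here, compound 4 carries none of these three groups, and no measured compound shows what 1-hydroxyethyl does, so these steps only loosely frame the expectation. Its group, like aminomethyl in compound 1 at 190 nM, is smaller than 1-aminocyclopentyl, which points to a higher number, of modest size and uncertain extent. The expected change is a 3.5-fold higher number from compound 3 to compound 4 (0.54 log units; beyond the scatter). For compound 4 the estimated value is 90 nM, with an expected range of 25 nM to 320 nM.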

Compound 4, half-maximal inhibitory concentration: 52 nM
Compound 4: the middle estimate sits 1.7-fold (0.24 log units) above what was measured; low and high end bracket the measured number.
By their numbers in this assay, from the lowest: compounds 2, 3 and 4 (each within the scatter of the next, the first and the last beyond it); then compound 1.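

In this assay, the group on the carbonyl carbon does not need a nitrogen or a ring to hold its level: 1-hydroxyethyl replaces 1-aminocyclopentyl with a 2.0-fold higher number from compound 3 to compound 4 (0.30 log units; within the scatter). Against the two other amines the picture is split, with a 2.5-fold higher number from compound 2 to compound 4 (0.39 log units; beyond the scatter) and a 3.7-fold lower number from compound 1 to compound 4 (0.56 log units; beyond the scatter), so 1-hydroxyethyl falls short of 1-amino-1-methylethyl yet clearly improves on aminomethyl. No supporting data on these compounds speak to what lies behind these differences.

The compounds shown leave open how the opposite stereocentre of 1-hydroxyethyl, or a methoxy group in place of its hydroxyl, would read here. From the compounds shown here alone, it also remains open whether a 1-hydroxy-1-methylethyl group would match 1-amino-1-methylethyl, as the pair of methyl groups might suggest.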